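Isopropyl for methyl on the aryl ring of a chromone acid

This account rests on a few compounds, and the source may have more. Where it says the series, first, only, none or still open, it means among the compounds named here.

Measured compounds in a functional assay on the whole organism (stomach) for inhibition, with Rattus norvegicus as the target, at a dose of 80 mg/kg; on this read-out higher numbers stand for more inhibition at the one dose given (going by the name of the read-out) and lower numbers for less inhibition:
compound 1, `Cc1ccc(-c2oc3ccc(C(=O)O)cc3c(=O)c2O)cc1`, gives 6%
compound 2, `CC(C)c1ccc(-c2oc3ccc(C(=O)O)cc3c(=O)c2O)cc1`, gives 24%
compound 3, `Cc1ccc(-c2oc3ccc(C(=O)O)cc3c(=O)c2OC(C)C)cc1`, gives 8%

The pair compound 1 and compound 2 differs by isopropyl in place of methyl on an aromatic carbon, and this assay moves by a number 18 percentage points higher from compound 1 to compound 2 (beyond the scatter). Compound 3 is built on the core of compound 1 with isopropyl in place of hydrogen on an oxygen on an aromatic ring, and the assay moves only by a number 2 percentage points higher from compound 1 to compound 3 (within the scatter), so compound 1 and compound 3 cannot be told apart here; compound 2 stands higher than compound 3 on the values alone.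

Compound 4, `CC(C)Oc1c(-c2ccc(C(C)C)cc2)oc2ccc(C(=O)O)cc2c1=O`, carries the change (isopropyl in place of methyl on an aromatic carbon). The place is the same word for word as in the change from compound 1 to compound 2, so it is the same change. Within the data shown here, compound 4 is expected to rise by about a number 16 percentage points higher from compound 3 to compound 4 (beyond the scatter) because a number 18 percentage points higher from compound 1 to compound 2 (beyond the scatter) is the only step of this kind seen, and it rests on one pair only. The estimate for compound 4 is 24%, from 10% to 38%.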

Compound 4, a percentage reported as inhibition, in the whole organism at one dose (the size of the read-out at that dose, not a potency): 20%
For compound 4 the middle estimate is 4 percentage points above the measured one; measured number inside the range.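

In this assay, isopropyl in place of methyl on an aromatic carbon again gives a step beyond the scatter, a number 12 percentage points higher from compound 3 to compound 4 (beyond the scatter), and it agrees with the step on the other core: the same change on two cores in this assay, a number 18 percentage points higher (beyond the scatter) from compound 1 to compound 2 and a number 12 percentage points higher (beyond the scatter) from compound 3 to compound 4, 6 percentage points apart, within the scatter of two such steps. Isopropyl in place of hydrogen on the oxygen gives a number 4 percentage points lower from compound 2 to compound 4 (within the scatter), and this also agrees with its earlier counterpart: the same change on two cores in this assay, a number 2 percentage points higher (within the scatter) from compound 1 to compound 3 and a number 4 percentage points lower (within the scatter) from compound 2 to compound 4, 6 percentage points apart, within the scatter of two such steps. Among these compounds, both changes therefore carry between these two cores, but each rests on only two pairs at one dose, which shows nothing about any other core.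

The compounds shown leave open what a longer chain or an amine would give on that aromatic carbon. They also leave open whether an amide in place of the carboxylic acid would leave these steps as they stand.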